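The source may report more compounds than this note shows. Statements on the series, on what has been measured and on what is new or still open speak of the compounds shown alone.

Three compounds that share one core are compared here. Compound 1 `Oc1cccc(-c2cc(-c3cccnc3)nc(-c3cccc(Cl)c3)c2)c1` has no result reported in an ADME assay on HEK293 cells (Homo sapiens) for cytotoxicity, read by CCK-8 assay and cell counting, with a stated time of 2 days (on this read-out lower numbers stand for stronger inhibition and higher numbers for weaker inhibition), where compound 1 stands as "not determined" (no result reported). Going by the values given here, compound 2 `Oc1ccc(-c2cc(-c3ccc(Cl)cc3)nc(-c3cccnc3)c2)cc1` is the only one with a number in this assay, where compound 2 gives 27500 nM. Since no second measured compound stands beside it, compound 2 stands alone on the numbers shown, and no measured step can be drawn from this set. Compound 3 `Oc1ccc(-c2cc(-c3cccnc3)nc(-c3cccc(Cl)c3)c2)cc1` has not yet been measured. It differs from compound 2 in one place, a rearrangement of the same atoms: 3-chlorophenyl in place of 4-chlorophenyl on an aromatic carbon. Among the compounds with values here, with only one measured value to lean on and no measured step of this kind, the expectation is that this change moves the read-out little, so the step is estimated as no change at the digits printed from compound 2 to compound 3 (within the scatter), no larger than the usual scatter. Compound 3 is therefore expected to give about 27500 nM in this assay, with a likely range from 12000 nM to 60000 nM.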

Compound 3, half-maximal inhibitory concentration: 25700 nM
The estimate for compound 3 lay 1.1-fold (0.03 log units) above the measured number; low and high end bracket the measured number.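

In this assay, shifting the chlorine on this phenyl group gives a 1.1-fold lower number from compound 2 to compound 3 (0.03 log units; within the scatter), so the 3-chlorophenyl and 4-chlorophenyl versions cannot be told apart on this read-out. Going by these compounds alone, this is the first measured step in the set, and it shows that at this aromatic carbon, next to the ring nitrogen, the place of the chlorine on the phenyl group makes no measurable difference for this pair. Nothing available offers an explanation for this result.

Compound 1, which carries its hydroxyl group at a different place, has no number, so that change cannot be read. Going by these compounds, it also remains open whether replacing the chlorophenyl group at this carbon with an amine or a carboxylic acid would shift the number in this assay beyond the usual scatter.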